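The source may report more compounds than this note shows. Statements on the series, on what has been measured and on what is new or still open speak of the compounds shown alone.

Compound 1 `Clc1ccc(Cn2c(CCc3c[nH]cn3)nnc2Cc2c[nH]c3ccccc23)cc1Cl` is one of two compounds that have been tested in an assay on cells for displacement of a labelled ligand from somatostatin receptor type 4 (Homo sapiens), with a stated time of 90 min; a higher number here means a weaker inhibitor, a lower number a stronger inhibitor. In this assay compound 1 gives > 10000 nM, which is a limit of the assay and not a number. Compound 2 `Clc1ccc(Cn2c(Cc3c[nH]c4ccccc34)nnc2C2CCNCC2)cc1Cl` differs from compound 1 by piperidin-4-yl in place of 2-(1H-imidazol-4-yl)ethyl on an aromatic carbon. In this assay compound 2 gives > 10000 nM, again a limit rather than a number. Going by the values given here, the one measured step, a step that the two limits leave unreadable from compound 1 to compound 2, therefore cannot be read in size or direction; the whole of the evidence is the limit of > 10000 nM in this assay, at which 2 of the 2 values shown sit. Compound 3 `c1ccc(Cn2c(CCc3c[nH]cn3)nnc2Cc2c[nH]c3ccccc23)cc1` differs from compound 1 by phenyl in place of 3,4-dichlorophenyl on a saturated chain carbon bound to an aromatic nitrogen. Among the compounds with values here, no measured step touches this change, so nothing in the data sets a size or a direction for it. Compound 1 stands only at a limit, and the expectation for compound 3 is that it stays there as well. The expected step is a step that the limit leaves unreadable from compound 1 to compound 3, a shift that a limit would not resolve. The estimate for compound 3 in this assay is 20000 nM, expected to lie between 5000 nM and 100000 nM.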

Compound 3, inhibition constant: > 10000 nM
Compound 3 gave a limit, no number (the forecaster's own chance of this, stated with the estimate: 85%); the middle value does not contradict the limit.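

In this assay, going by these compounds alone, compound 3 gives > 10000 nM, a limit and not a number, and compound 1 also stands only at a limit, so no step from compound 1 to compound 3 can be read. The compounds shown leave open whether any change to the shared core would give a readable number, as the evidence stands: the limit of > 10000 nM in this assay, at which 3 of the 3 values shown sit.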